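Dropping One Chlorine from a Dichlorophenyl Thioether

The source may report more compounds than this note shows. Statements on the series, on what has been measured and on what is new or still open speak of the compounds shown alone.

Within the data shown here, of the two compounds measured so far, compound 2 `OC[C@H]1O[C@@H](n2cnc3c(CSc4ccc(Cl)c(Cl)c4)ncnc32)[C@H](O)[C@@H]1O` stands lowest in an assay on isolated protein for binding affinity to Equilibrative nucleoside transporter 1 (Homo sapiens); a lower number here means a stronger inhibitor, a higher number a weaker inhibitor: compound 2 gives 224 nM. Among the measured compounds shown here, the only other number belongs to compound 1 `Cc1cccc(CSc2ncnc3c2ncn3[C@@H]2O[C@H](CO)[C@@H](O)[C@H]2O)c1`, which in this assay gives 12000 nM, a far higher figure that lies well beyond the usual scatter of the measurement. Compound 1 also differs from compound 2 in more than one place, so its value says little about any single change.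

Compound 3 `OC[C@H]1O[C@@H](n2cnc3c(CSc4cccc(Cl)c4)ncnc32)[C@H](O)[C@@H]1O` is the closer relative. It differs from compound 2 by hydrogen in place of chloro on an aromatic carbon. For the measured compounds named here, no measured pair covers this change, so its size must be guessed rather than read off. Removing one of the two chloro groups from the aryl thioether is a small trimming of the structure, and the expectation is a modest loss of binding, although a result within the scatter would not be surprising.

For compound 3 the estimated value in this assay is 600 nM, with a likely range from 200 nM to 2000 nM; this corresponds to an expected step of a 2.7-fold higher number from compound 2 to compound 3 (0.43 log units; beyond the scatter) toward weaker inhibition.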

Compound 3, half-maximal inhibitory concentration: 282 nM
For compound 3 the middle estimate is 2.1-fold (0.33 log units) above the measured one; the range from low to high includes it.
By their numbers in this assay, from the lowest: compounds 2 and 3 (each within the scatter of the next); then compound 1.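

In this assay, going from (3,4-dichlorophenyl)sulfanyl to (3-chlorophenyl)sulfanyl gives a 1.3-fold higher number from compound 2 to compound 3 (0.10 log units; within the scatter), so in this pair, replacing the chloro para to a large group with hydrogen has no effect that can be told from the scatter. The wide gap between compound 1 and compound 2 is therefore not explained by this chloro, since the single remaining chloro still leaves a 43-fold lower number from compound 1 to compound 3 (1.63 log units; beyond the scatter), a large step beyond the scatter, in which one whole group of equal heavy-atom count takes the place of another, so the step cannot be pinned on any one part of that group. No supporting measurement bears on why this chloro can be given up without a visible change.

The compounds shown leave open whether the other chloro can also be replaced by hydrogen, and whether a methyl, a methoxy or an amine in the vacated place would behave as hydrogen does here. They also leave open which part of the group that separates compound 1 from compound 3 carries the large step.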